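The compounds below may be only part of what the source reports. "The series", "measured", "known", "first", "only" and "open" are said of these compounds alone.

Compound 2, `Cc1cc(O)c(-n2c(N)nc3ccccc32)cc1C`, and its close relative compound 1, `Cc1cc(C)c(O)c(-n2c(N)nc3ccccc32)c1`, have both been tested in a physicochemical assay for solubility, read by nephelometry, measured as kinetic solubility, with a stated time of 30 min, at pH 2; a lower number here means a less soluble compound, a higher number a more soluble compound. In this assay compound 1 gives > 100 ug/mL, which is a limit of the assay rather than a number. In this assay compound 2 likewise gives > 100 ug/mL, again a limit of the assay and not a number. Where compound 2 stands is therefore known only as a limit: both values sit at the limit of > 100 ug/mL in this assay, at which 2 of the 2 values shown sit, and no difference between the two compounds can be read from them.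

Compound 3, `Cc1ccc(-n2c(N)nc3ccccc32)c(O)c1`, has not yet been measured in this assay. It differs from compound 2 in one place: hydrogen in place of methyl on an aromatic carbon. With both measured compounds at the limit, no step beyond the scatter is expected, and the step is estimated as a step that the limit leaves unreadable from compound 2 to compound 3. Compound 3 is expected to give about 150 ug/mL in this assay, within a range of 70 ug/mL to 320 ug/mL, most likely reported again only as a limit.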

Compound 3, solubility: > 100 ug/mL
Compound 3: a limit, no number; the forecaster's own chance of this, stated with the estimate: 80%; the middle value is on the limit's open side.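

In this assay, among the compounds shown here, compound 3 gives > 100 ug/mL, which is a limit of the assay, so no step from compound 2 to compound 3 can be read: the limit of > 100 ug/mL in this assay, at which 3 of the 3 values shown sit. As far as these compounds go, whether compounds 1, 2 and 3 differ at all in solubility remains open.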